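A dicyanoethenyl swap at the assay limit

The source may hold more compounds than are shown below. What is called first, only, known or untested is meant among the compounds shown, and "the series" means these compounds.

In a functional assay on A549 cells (Homo sapiens) for cytotoxicity, read by sulforhodamine B assay (on this read-out higher numbers stand for weaker inhibition of growth and lower numbers for stronger inhibition of growth), compound 1 (`CCOC(=O)/C(C#N)=C/c1ccccc1-c1c(/C=C(\C#N)C(=O)OCC)cc(OC)c(OC)c1OC`) gives 7020 nM as a measured number. Compound 3 (`CCOC(=O)/C(C#N)=C/c1ccccc1-c1c(C(=O)OC)cc(OC)c(OC)c1OC`) reads > 40000 nM and this is a limit, not a number. Compound 2 (`COc1cc(C=C(C#N)C#N)c(-c2ccccc2C=C(C#N)C#N)c(OC)c1OC`) reads > 40000 nM and this too is a limit. Compound 3 therefore stands at the top of the range (see (the limit of > 40000 nM in this assay, at which 2 of the 3 values shown sit)) with no exact value of its own.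

Compound 4 (`COC(=O)c1cc(OC)c(OC)c(OC)c1-c1ccccc1C=C(C#N)C#N`) keeps the methoxycarbonyl of compound 3 and carries 2,2-dicyanoethenyl in place of 2-cyano-2-(ethoxycarbonyl)ethenyl on an aromatic carbon is the whole change. Among the compounds with values here, the one measured step that bears on it is an at least 5.6-fold higher number from compound 1 to compound 3 (0.75 log units; beyond the scatter) and it shows that the methoxycarbonyl arm goes with the loss of a measurable value. The same 2,2-dicyanoethenyl group appears in compound 2, whose value > 40000 nM offers no sign of recovery. No step beyond the scatter is therefore expected in this assay. The expected change is a number no higher from compound 3 to compound 4 (the limit leaves the size open) and it should remain close to the limit. For compound 4 the estimate is 40000 nM with an expected range of 18000 nM to 80000 nM and a limit is the likeliest report.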

Compound 4, concentration for 50% growth inhibition: 42000 nM
For compound 4 the middle estimate is 1.1-fold (0.02 log units) below the measured one; the range from low to high includes it.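

Neither new step to compound 4, from compound 3 or from compound 2, can be read in this assay, as each of those two compounds reports only a limit. The compounds shown leave open how far 2,2-dicyanoethenyl in place of 2-cyano-2-(ethoxycarbonyl)ethenyl shifts growth inhibition.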